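A few compounds are considered here, and "the series" means these few. Any claim that something is new, unique, unknown or untested is made for them only; others in the source may bear on it.

In an ADME assay on PANC-1 cells (Homo sapiens) for cytotoxicity, read by MTT assay (a lower number here means that less compound is tolerated, a higher number that more compound is tolerated), compound 2 (`Cc1nc(-c2cccnc2)sc1-c1nnc(-c2ccc(O)cc2)o1`) reaches only the limit of the measurement, > 100 ug/mL, so no number is known for it. Compound 1 (`Cc1nc(-c2cccnc2)sc1-c1nnc(-c2ccc(Br)cc2)o1`) likewise sits at the limit, > 100 ug/mL. The step that the two limits leave unreadable from compound 1 to compound 2 therefore cannot be sized, and the limit of > 100 ug/mL in this assay, at which 2 of the 2 values shown sit, is the whole of the evidence. Compound 3 (`Cc1nc(-c2cccnc2)sc1-c1nnc(-c2ccncc2)o1`) differs from compound 2 by pyridin-4-yl in place of 4-hydroxyphenyl on an aromatic carbon. With both measured neighbours at the limit, no step beyond the scatter is expected in this assay. Compound 3 is expected to give 150 ug/mL, between 50 ug/mL and 400 ug/mL, an estimated step that the limit leaves unreadable from compound 2 to compound 3.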

Compound 3, half-maximal cytotoxic concentration: > 100 ug/mL
Compound 3 ended at the assay's limit; the forecaster's own chance of this, stated with the estimate: 85%; the middle value is on the limit's open side.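

Among these compounds, compound 1, compound 2 and compound 3 all end at a limit in this assay, so no step among them can be read: the limit of > 100 ug/mL in this assay, at which 3 of the 3 values shown sit. The compounds shown leave open whether the 4-bromophenyl, 4-hydroxyphenyl and pyridin-4-yl compounds differ at all in this assay.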